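Swapping a bicyclic amide for an oxolane ring

The source may report more compounds than this note shows. Statements on the series, on what has been measured and on what is new or still open speak of the compounds shown alone.

Of the compounds shown here, three have been measured in an assay on CHO cells for displacement of a labelled ligand from histamine receptor H3 (Macaca mulatta); a lower number here means a stronger inhibitor, a higher number a weaker inhibitor. Compound 1 `Cc1cc(NC(=O)C2CC3CCC2C3)ccc1N1CCC(N2CCCC2C)C1` gives 130 nM, compound 2 `CC(=O)N1CCCC1C(=O)Nc1ccc(N2CCC(N3CCCC3C)C2)cc1` gives 14.1 nM, and compound 3 `Cc1cc(N2CCC(N3CCCC3C)C2)ccc1NC(=O)C1CC2CCC1C2` gives 19.9 nM. Compound 3 thus holds the second highest number of the three; its value and that of compound 2 lie within the usual scatter, while compound 1 sits well apart with a higher number. Compound 4 `Cc1cc(N2CCC(N3CCCC3C)C2)ccc1NC(=O)C1CCCO1` has not yet been measured. It differs from compound 3 in one place: a group of 5 heavy atoms (4 carbon, 1 oxygen; one five-membered non-aromatic ring with 1 hetero atom) in place of a group of 7 heavy atoms (7 carbon; 2 five-membered non-aromatic rings of carbon only), on a carbonyl carbon. Compound 2 shows that an amide bearing a small hetero ring can give a low number, so only a modest rise in this assay is expected for compound 4, as the step of a 1.5-fold higher number from compound 3 to compound 4 (0.18 log units; within the scatter) suggests. Compound 4 is estimated at 30 nM, within 8 nM to 110 nM.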

Compound 4, inhibition constant: 7.34 nM
The estimate for compound 4 lay 4.1-fold (0.61 log units) above the measured number; measured number below the stated range.
By their numbers in this assay, from the lowest: compounds 4, 2 and 3 (each within the scatter of the next, the first and the last beyond it); then compound 1.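

On the carbonyl carbon of the amide, putting oxolan-2-yl in place of the two-ring carbon group gives a 2.7-fold lower number from compound 3 to compound 4 (0.43 log units; beyond the scatter) in this assay, a modest change but one beyond the scatter. The two-ring carbon group is therefore not needed at this place for a low number, and a smaller group with a single ring does better. Nothing measured here explains the change.

Going by these compounds, whether the ring oxygen matters, or only the smaller group, remains open; a plain cyclopentyl ring on the same carbonyl carbon would separate the two.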